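From an aryl amine to pyrrolidine on a shared core

The compounds below may be only part of what the source reports. "The series", "measured", "known", "first", "only" and "open" are said of these compounds alone.

- compound 1 `COc1ccccc1NC1=CC(=O)c2nc3n(c2C1=O)[C@H]1OC[C@@H](O)[C@H]1OC3` gives 2950 nM as its value
- compound 2 `O=C1C=C(Nc2cccc(Cl)c2)C(=O)c2c1nc1n2[C@H]2OC[C@@H](O)[C@H]2OC1` gives 6040 nM as its value
- compound 3 `O=C1C=C(N2CCCC2)C(=O)c2c1nc1n2[C@H]2OC[C@@H](O)[C@H]2OC1` has no value yet

In a functional assay on HeLa cells (Homo sapiens) for inhibition, read by sulforhodamine B assay (on this read-out lower numbers stand for stronger inhibition and higher numbers for weaker inhibition), compound 2 stands at 6040 nM as the higher of the two numbers, which makes it the weaker inhibitor of the measured pair. Compound 3 carries pyrrolidin-1-yl in place of (3-chlorophenyl)amino on a double-bonded ring carbon, and the count of that change reads pyrrolidin-1-yl in place of (3-chlorophenyl)amino on a double-bonded ring carbon in full. Within the data shown here, only one measured step exists, a 2.0-fold higher number from compound 1 to compound 2 (0.31 log units; beyond the scatter) by placing 3-chlorophenyl in place of 2-methoxyphenyl on an amine nitrogen. Among the measured compounds shown here, that step is modest and bears only loosely on the new change, since no measured compound carries pyrrolidin-1-yl. Going by these compounds, the data therefore give no direction, and no shift beyond the scatter is expected in this assay even though a larger move either way remains open. The expected step is a 1.2-fold lower number from compound 2 to compound 3 (0.08 log units; within the scatter) by this estimate. Compound 3 is estimated at 5000 nM with an expected range from 1500 nM to 17000 nM on this measure.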

Compound 3, half-maximal inhibitory concentration: > 16000 nM
Compound 3 gave a limit, no number; the forecaster's own chance of this, stated with the estimate: 10%; middle value at least 3.2-fold (0.50 log units) from the limit.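

In this assay compound 3 gives a limit and not a number: the limit of > 16000 nM in this assay, at which 1 of the 3 values shown sits.

Pyrrolidin-1-yl on the double-bonded ring carbon gives an at least 2.6-fold higher number from compound 2 to compound 3 (0.42 log units; beyond the scatter) when it replaces (3-chlorophenyl)amino, and an at least 5.4-fold higher number from compound 1 to compound 3 (0.73 log units; beyond the scatter) when it replaces (2-methoxyphenyl)amino. Among these compounds, the earlier compounds showed only a change from one arylamino group to another, a 2.0-fold higher number from compound 1 to compound 2 (0.31 log units; beyond the scatter), so this result is the first sign that inhibition at this position also depends on the kind of amino group, with both arylamino compounds giving lower numbers than compound 3.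

The change removes the aromatic ring and the hydrogen-bond donor of the leaving group together, so the compounds shown cannot tell which of the two matters, and a cyclohexylamino group, which keeps the amine hydrogen on a non-aromatic ring, would separate them. Going by these compounds, how far compound 3 lies beyond its limit also stays open, as does whether an open-chain amine such as diethylamino or a ring amine such as morpholine would behave as pyrrolidin-1-yl does.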